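The source may report more compounds than this note shows. Statements on the series, on what has been measured and on what is new or still open speak of the compounds shown alone.

Compound 1 `CCSc1nnc(COc2ccccc2C2=NOC(c3ccc(Cl)cc3Cl)C2)n1NC(C)=O` and compound 2 `CCCCSc1nnc(COc2ccccc2C2=NOC(c3ccc(Cl)cc3Cl)C2)n1NC(=O)c1ccccc1` share a core and differ at two points: the chain on the sulfur and the acyl group on the amide nitrogen. In an ADME assay (MDM cells, Homo sapiens) for cytotoxicity, read by resazurin assay, with a stated time of 3 days (on this read-out higher numbers stand for weaker inhibition and lower numbers for stronger inhibition), compound 1 gives 9.7 ug/mL, while compound 2 gives 2.5 ug/mL. Compound 2 therefore holds the lowest of the two numbers recorded so far, and the gap to compound 1 falls beyond the usual scatter of repeated runs. The two compounds differ in two places at once. Within the data shown here, no single step between them can be read off.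

Compound 3 `CCSc1nnc(COc2ccccc2C2=NOC(c3ccc(Cl)cc3Cl)C2)n1NC(=O)c1ccccc1` has not yet been measured in this assay. It is reached from compound 2 by one change, (hydrogen in place of ethyl on a saturated chain carbon, two bonds along the chain from a sulfur), so that compound 3 carries the sulfur chain of compound 1 together with the amide acyl group of compound 2. A modest step is expected from compound 2 to compound 3, a 1.8-fold higher number from compound 2 to compound 3 (0.26 log units; within the scatter), toward weaker inhibition, since compound 3 sits structurally between compound 2 at 2.5 ug/mL and compound 1 at 9.7 ug/mL. Compound 3 is accordingly estimated at 4.5 ug/mL, within a range from 2 ug/mL to 10 ug/mL.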

Compound 3, half-maximal inhibitory concentration: 1.8 ug/mL
Beside the measured number, compound 3's estimate is 2.5-fold (0.40 log units) above it; the measured number lies below the stated range.
By their numbers in this assay, from the lowest: compounds 3 and 2 (each within the scatter of the next); then compound 1.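

In this assay, the exchange of butylsulfanyl for ethylsulfanyl, with hydrogen in place of ethyl on a saturated chain carbon, two bonds along the chain from a sulfur, gives a 1.4-fold lower number from compound 2 to compound 3 (0.14 log units; within the scatter) and so leaves compound 2 and compound 3 indistinguishable at this position. The other single-place comparison, phenyl in place of methyl on a carbonyl carbon, gives a 5.4-fold lower number from compound 1 to compound 3 (0.73 log units; beyond the scatter) and is the only one of the two steps that lies beyond the scatter, so among these three compounds a readable difference appears at the acyl group and not on the sulfur chain. Nothing available explains the size of either step.

On these data alone, each step rests on a single pair, so it remains open whether the butyl and ethyl chains would also read alike with methyl on the carbonyl carbon, and whether a longer chain, such as hexyl, or a chain ending in an amine or a carboxylic acid would keep the read-out unchanged. The acyl position is likewise defined only by methyl and phenyl, which leaves groups such as cyclohexyl or pyridyl on the carbonyl carbon unaddressed.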